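Methyl in Place of Nitrile on the Benzyl Ring

The source may hold more compounds than are shown below. What is called first, only, known or untested is meant among the compounds shown, and "the series" means these compounds.

Of the compounds shown here, three sharing one core have so far been tested in a functional assay on the whole organism (strain NMRI) with Mus musculus as the target, with a stated time of 0.5 h; on this read-out lower numbers stand for an effect already at smaller amounts and higher numbers for an effect only at larger amounts of compound. Compound 1 `COc1ccc(Cn2cc(CO/N=C/c3c(-c4ccccc4)nc4c(C)cccn34)nn2)cc1` gives 40 mg/kg. Compound 2 `Cc1ccc(-c2nc3ccc(Br)cn3c2/C=N/OCc2cn(Cc3ccc([N+](=O)[O-])cc3)nn2)cc1` gives 20 mg/kg, and compound 3 `Cc1ccc(-c2nc3ccc(Br)cn3c2/C=N/OCc2cn(Cc3ccc(C#N)cc3)nn2)cc1` gives 40 mg/kg. The only single-point comparison among them is a 2.0-fold higher number from compound 2 to compound 3 (0.30 log units; within the scatter), so all three numbers sit within the usual scatter of one another, and compound 3 stands level with compound 1 at the digits shown.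

Compound 4 `Cc1ccc(Cn2cc(CO/N=C/c3c(-c4ccc(C)cc4)nc4ccc(Br)cn34)nn2)cc1` differs from compound 3 in one place: methyl in place of cyano on an aromatic carbon. Among the compounds with values here, no measured pair shows this change; the one known step, from nitro to cyano on the same aromatic carbon, stayed within the scatter, and nothing in the data points to a move beyond it for methyl in place of cyano. The step from compound 3 to compound 4 is therefore expected to be no change at the digits printed from compound 3 to compound 4 (within the scatter), with no shift beyond the scatter. Compound 4 is estimated to give 40 mg/kg in this assay, in a range from 20 mg/kg to 80 mg/kg.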

Compound 4, minimum effective dose: 40 mg/kg
Estimate against measurement, compound 4: no gap at the digits printed, and the stated range covers the measured number.
By their numbers in this assay, from the lowest: compounds 2, 1, 3 and 4 (each within the scatter of the next).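

Until now, this place on the benzyl ring had shown only a change from nitro to nitrile. In this assay methyl in place of nitrile gives no change at the digits printed from compound 3 to compound 4 (within the scatter) and methyl in place of nitro gives a 2.0-fold higher number from compound 2 to compound 4 (0.30 log units; within the scatter) at the same carbon, so a group with no hydrogen-bond acceptor and no triple bond also stays within the scatter. The data hold no measurement that could explain why the numbers stay so close.

As far as these compounds go, whether an amine, a carboxylic acid or a longer chain at this place would also stay within the scatter remains open. Also open, from the compounds shown here alone, is whether a swap to methyl would read the same on the core of compound 1, which differs from the others in more than one place.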